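A phenyl-ended chain on compound 1

A few compounds are considered here, and "the series" means these few. Any claim that something is new, unique, unknown or untested is made for them only; others in the source may bear on it.

Compound 1 (`CCCCCCCCC#Cc1cn(C/C=C\CN2C(=O)c3ccccc3C2=O)c(=O)[nH]c1=O`) gives 45000 nM
Compound 2 (`CCCCCCCCC#Cc1cn(C/C=C/CN2C(=O)c3ccccc3C2=O)c(=O)[nH]c1=O`) gives > 250000 nM as a limit
Compound 3 (`CCCCCc1ccc(C#Cc2cn(C/C=C/CN3C(=O)c4ccccc4C3=O)c(=O)[nH]c2=O)cc1`) gives 39000 nM

In a functional assay on L1210 cells (Mus musculus) for antiproliferative activity, read by MTT assay, with a stated time of 2 days (on this read-out lower numbers stand for stronger inhibition and higher numbers for weaker inhibition), compound 1 and compound 3 lie within the scatter of each other, while compound 2 reports only a limit. Compound 4 (`O=C1c2ccccc2C(=O)N1C/C=C\Cn1cc(C#CCCc2ccccc2)c(=O)[nH]c1=O`) keeps the Z double bond of compound 1 and carries phenyl in place of hexyl on a saturated chain carbon, two bonds along the chain from a triple-bonded carbon. The nearest measured step (an at least 6.4-fold lower number from compound 2 to compound 3 (0.80 log units; beyond the scatter)) put 4-pentylphenyl in place of octyl on a triple-bonded carbon, but it starts from a limit on the E double bond. The other step (an at least 5.5-fold higher number from compound 1 to compound 2 (0.74 log units; beyond the scatter)) goes with the fact that compounds 1 and 2 differ only in the configuration as drawn and leaves the chain untouched. In this assay no step beyond the scatter is therefore expected. The expected step is small (a 1.1-fold higher number from compound 1 to compound 4 (0.05 log units; within the scatter)). Compound 4 is estimated at 50000 nM (expected range 18000 nM to 170000 nM).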

Compound 4, half-maximal inhibitory concentration: 143000 nM
Estimate against measurement, compound 4: 2.9-fold (0.46 log units) below, within the range that was stated.
By their numbers in this assay, from the lowest: compounds 3 and 1 (each within the scatter of the next); then compound 4. At a limit, above all of these: compound 2.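

In this assay, the chain keeps its influence with the Z double bond in place: phenyl in place of hexyl on a saturated chain carbon, two bonds along the chain from a triple-bonded carbon, gives a 3.2-fold higher number from compound 1 to compound 4 (0.50 log units; beyond the scatter). Among the compounds shown here, this is the first chain change read between two numbers rather than from a limit, and it comes with no change in heavy-atom count. Nothing shown explains this step.

From the compounds shown here alone, whether a longer chain ending in phenyl or an amine at the chain end would shift the number stays open. So does how the 4-pentylphenyl group would read on the Z double bond.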